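Swapping Oxygen for Sulfur in a Sulfonyl-Linked Ring

The source may report more compounds than this note shows. Statements on the series, on what has been measured and on what is new or still open speak of the compounds shown alone.

Measured compounds:
compound 1, `O=S(=O)(CC1=NCCO1)c1n[nH]cc1-c1ccc(Cl)cc1`: "not active" (no number reported) in a functional assay, read by Griess assay, with a stated time of 150 min, tested at 100 ug/mL; a lower number here means a weaker effect, a higher number a stronger effect of the compound at the concentration tested
compound 2, `O=S(=O)(CC1=NCCO1)c1n[nH]cc1-c1ccccc1`: 57.5% in this assay

Of the compounds shown here, two of the same shared core have been tested. In this assay compound 1 was reported as "not active" (no number reported), so no number stands for it, only the word that nothing measurable was seen. Compound 2, which carries an unsubstituted phenyl ring in place of the chlorinated one, gives 57.5% in this assay. Within the data shown here, the pair differs in more than one respect, so only these two results are set side by side here, and no computed step between them is given.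

Compound 3, `O=S(=O)(CC1=NCCS1)c1n[nH]cc1-c1ccc(Cl)cc1`, has not been measured yet. It differs from compound 1 by a group of 5 heavy atoms (3 carbon, 1 nitrogen, 1 sulfur; one five-membered non-aromatic ring with 2 hetero atoms) in place of a group of 5 heavy atoms (3 carbon, 1 nitrogen, 1 oxygen; one five-membered non-aromatic ring with 2 hetero atoms), on a saturated chain carbon bound to a sulfonyl sulfur. Among the measured compounds shown here, no measured pair shows what this exchange does, so the size of the step in this assay is unknown; a modest change in either direction, or none beyond the scatter, is all that can be expected from what is known. Because compound 1 was reported as "not active" (no number reported), compound 3 is estimated at 20%, with a range from 0% to 55%.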

Compound 3, a percentage reported as activity, at one concentration (the size of the read-out at that concentration, not a potency): "not active" (no number reported)
Nothing numeric was reported for compound 3; the estimate stays without a comparison.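

Compound 1 gives "not active" (no number reported) in this assay and compound 3 gives "not active" (no number reported) so no step can be read between these two compounds. The compounds shown leave open what exchanging oxygen for sulfur in the five-membered ring does when the starting compound has a measurable value, as compound 2 has. No supporting data bear on this result.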